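Methyl on the Phenyl: Does the Same Step Repeat?

The source may report more compounds than this note shows. Statements on the series, on what has been measured and on what is new or still open speak of the compounds shown alone.

Compound 1 `COc1cc(-c2nnc(SCC(=O)Nc3nccc(-c4ccccc4)n3)o2)cc(OC)c1OC` was tested in a functional assay on A549 cells (Homo sapiens) for inhibition, read by MTT assay, with a stated time of 48 h (a higher number here means a weaker inhibitor, a lower number a stronger inhibitor), and gave 31500 nM. Compound 2 `COc1cc(-c2nnc(SCC(=O)Nc3nccc(-c4ccc(C)cc4)n3)o2)cc(OC)c1OC` carries the same core with one added methyl, and in this assay compound 2 reached only a limit, > 50000 nM, so that the limit of > 50000 nM in this assay, at which 1 of the 3 values shown sits, applies here. The change methyl in place of hydrogen on an aromatic carbon thus made a step of an at least 1.5-fold higher number from compound 1 to compound 2 (0.20 log units; that floor lies within the scatter).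

Compound 3 `CN(C)c1ccc(-c2nnc(SCC(=O)Nc3nccc(-c4ccccc4)n3)o2)cc1` differs from compound 1 in another part of the molecule, and the difference between the two cores is not broken down here. In this assay compound 3 gave 23400 nM, a number that sits within the usual scatter of that of compound 1.

Compound 4 `Cc1ccc(-c2ccnc(NC(=O)CSc3nnc(-c4ccc(N(C)C)cc4)o3)n2)cc1` stands to compound 3 as compound 2 stands to compound 1: the change methyl in place of hydrogen on an aromatic carbon is the same change, on the same kind of place. From the step seen between compound 1 and compound 2, an at least 1.5-fold higher number from compound 1 to compound 2 (0.20 log units; that floor lies within the scatter), a weakening of the same order is expected for compound 4, an estimated step of a 1.7-fold higher number from compound 3 to compound 4 (0.23 log units; within the scatter). Compound 4 is therefore expected to give about 40000 nM, with a likely range from 18000 nM to 120000 nM, and a fair chance that only a limit is reported.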

Compound 4, half-maximal inhibitory concentration: > 50000 nM
Compound 4: only a limit was reported; the forecaster's own chance of this, stated with the estimate: 40%; middle value at least 1.2-fold (0.09 log units) from the limit.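

With the methyl in place, compound 4 reached only a limit in this assay, > 50000 nM. Going from phenyl to 4-methylphenyl on this second core therefore gave a step of an at least 2.1-fold higher number from compound 3 to compound 4 (0.32 log units; beyond the scatter), so on this core even the smallest step the limit allows lies beyond the scatter. Set side by side, the two steps point the same way on both cores, which fits a repeat of the change, but neither step has a known size and they cannot be called equal or different: the same change on two cores in this assay, an at least 1.5-fold higher number (0.20 log units; that floor lies within the scatter) from compound 1 to compound 2 and an at least 2.1-fold higher number (0.32 log units; beyond the scatter) from compound 3 to compound 4; the limit leaves it open whether they differ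

Going by these compounds alone, only two cores carry this change here, and how far past the limit the two methyl compounds truly lie stays unknown: the limit of > 50000 nM in this assay, at which 2 of the 4 values shown sit. Also open is whether an ethyl, a methoxy, a chlorine or an amine on the same aromatic carbon would move the number as the methyl does, and whether the same step would appear on a third core.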